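Swapping an ester for tert-butyl on the aryl ring

A few compounds are considered here, and "the series" means these few. Any claim that something is new, unique, unknown or untested is made for them only; others in the source may bear on it.

Measured compounds in a functional assay on HeLa cells (Homo sapiens) for inhibition; on this read-out higher numbers stand for weaker inhibition and lower numbers for stronger inhibition:
compound 1 `CC(C)c1ccc(N2C(=O)C=CC2OCC(F)(F)F)cc1` gives 5800 nM
compound 2 `O=C1C=CC(OCC(F)(F)F)N1c1ccc([N+](=O)[O-])cc1` gives 2380 nM
compound 3 `COC(=O)c1ccc(N2C(=O)C=CC2OCC(F)(F)F)cc1` gives 5700 nM

Compound 3 stands second highest of the three numbers in this assay. Its nearest neighbour is compound 1, whose number sits within the scatter of its own (a 1.0-fold lower number from compound 1 to compound 3 (0.01 log units; within the scatter)); its furthest is compound 2, reached by a 2.4-fold higher number from compound 2 to compound 3 (0.38 log units; beyond the scatter).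

Compound 4 `CC(C)(C)c1ccc(N2C(=O)C=CC2OCC(F)(F)F)cc1` is not yet measured. It differs from compound 3 in one place: tert-butyl in place of methoxycarbonyl on an aromatic carbon.

The step that bears most on this change is a 1.0-fold lower number from compound 1 to compound 3 (0.01 log units; within the scatter), which shows that replacing isopropyl with methoxycarbonyl did not move the number beyond the scatter. Tert-butyl, like isopropyl, is a group of carbon only, so the change from compound 3 to compound 4 is expected to behave like the reverse of that step, with no shift beyond the scatter: no change at the digits printed from compound 3 to compound 4 (within the scatter). Compound 4 is therefore estimated at 5700 nM in this assay, within a range of 2500 nM to 13000 nM.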

Compound 4, half-maximal inhibitory concentration: 18100 nM
For compound 4 the middle estimate is 3.2-fold (0.50 log units) below the measured one; measured number outside the range, above it.
By their numbers in this assay, from the lowest: compound 2; then compounds 3 and 1 (each within the scatter of the next); then compound 4.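

In this assay, this position on the aromatic ring proves sensitive to the choice of group: although compound 1 and compound 3 sit within the scatter of each other, tert-butyl gives a 3.2-fold higher number from compound 3 to compound 4 (0.50 log units; beyond the scatter). A single added methyl separates the two carbon-only groups, yet it gives a 3.1-fold higher number from compound 1 to compound 4 (0.49 log units; beyond the scatter), and the distance from the nitro compound widens to a 7.6-fold higher number from compound 2 to compound 4 (0.88 log units; beyond the scatter), leaving compound 4 as the weakest inhibitor of the four. No measurement here explains why one extra methyl matters so much.

The compounds shown leave open whether a still larger carbon group, such as a cyclohexyl ring, would weaken inhibition further. They also leave open how an amine or a carboxylic acid would behave at this position.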